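Amine swap on the acrylamide side chain

This account rests on a few compounds, and the source may have more. Where it says the series, first, only, none or still open, it means among the compounds named here.

For the measured compounds named here, compound 2 `CN(C)C/C=C/C(=O)Nc1cc2c(N3CCc4ccccc43)ncnc2cc1O[C@@H]1CCOC1` gives the lowest of the two numbers so far in a functional assay on PC-3 cells (Homo sapiens) for antiproliferative activity, read by MTT assay, with a stated time of 72 h (a lower number here means a stronger inhibitor, a higher number a weaker inhibitor), at 1230 nM. Its nearest neighbour, compound 1 `C/C=C/C(=O)Nc1cc2c(N3CCc4ccccc43)ncnc2cc1O[C@@H]1CCOC1`, gives 5220 nM in this assay, the step of a 4.2-fold lower number from compound 1 to compound 2 (0.63 log units; beyond the scatter) being the only one measured. Compound 3 `CCN(CC)C/C=C/C(=O)Nc1cc2c(N3CCc4ccccc43)ncnc2cc1O[C@@H]1CCOC1` differs from compound 2 by diethylamino in place of dimethylamino on a saturated chain carbon bound to a double-bonded chain carbon. Going by the values given here, no measured step covers this exchange of one amine for another; the one step on record concerns adding the amine, not enlarging it. The expected step of a 1.0-fold lower number from compound 2 to compound 3 (0.01 log units; within the scatter) therefore lies within the scatter. Compound 3 is estimated at 1200 nM (range 500 nM to 3000 nM) in this assay.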

Compound 3, half-maximal inhibitory concentration: 5780 nM
For compound 3 the middle estimate is 4.8-fold (0.68 log units) below the measured one; measured number outside the range, above it.
By their numbers in this assay, from the lowest: compound 2; then compounds 1 and 3 (each within the scatter of the next).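

The position on a saturated chain carbon bound to a double-bonded chain carbon distinguishes one amine from another: in this assay diethylamino in place of dimethylamino gives a 4.7-fold higher number from compound 2 to compound 3 (0.67 log units; beyond the scatter), so the presence of an amine alone does not set the number. Diethylamino in place of hydrogen gives a 1.1-fold higher number from compound 1 to compound 3 (0.04 log units; within the scatter), which leaves these two compounds level within the scatter. No available evidence bears on this difference between the two amines.

From the compounds shown here alone, whether ring amines such as pyrrolidine, piperidine or morpholine at this place track dimethylamino or diethylamino remains open. So does the reading for a mixed amine such as ethylmethylamino.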